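Thiosemicarbazone series: loss of the methylamino group

This account rests on a few compounds, and the source may have more. Where it says the series, first, only, none or still open, it means among the compounds named here.

Measured in a functional assay on MIA PaCa-2 cells (Homo sapiens) for cytotoxicity, read by luminescence, with a stated time of 72 h; a higher number here means a weaker inhibitor, a lower number a stronger inhibitor:
compound 1 `CNC(=S)N/N=C/c1nccc2cc(F)ccc12` gives 4080 nM
compound 2 `CN(C)C(=S)NN=Cc1nccc2ccccc12` gives 29600 nM
compound 3 `CNc1cccc2c(C=NNC(=S)N(C)C)ncc(F)c12` gives 327 nM

Compound 3 has the lowest number of the three; its gaps to compound 1, the nearest, and to compound 2, the furthest, both lie beyond the scatter, so compound 3 is the strongest inhibitor in this set. Compound 4 `CN(C)C(=S)NN=Cc1ncc(F)c2ccccc12` differs from compound 3 in one place: hydrogen in place of methylamino on an aromatic carbon. Among the compounds with values here, no measured pair covers exactly this change. Compound 2, which also lacks the methylamino group, gives the highest number of the three, whereas compound 3 gives the lowest; a loss of potency well beyond the scatter is therefore expected, a 24-fold higher number from compound 3 to compound 4 (1.39 log units; beyond the scatter). Compound 4 is estimated at 8000 nM, with a range of 2000 nM to 30000 nM.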

Compound 4, concentration for 90% inhibition: 274 nM
Beside the measured number, compound 4's estimate is 29-fold (1.47 log units) above it; the whole stated range lies above it.
By their numbers in this assay, from the lowest: compounds 4 and 3 (each within the scatter of the next); then compound 1; then compound 2.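

In this assay hydrogen in place of methylamino on an aromatic carbon gives a 1.2-fold lower number from compound 3 to compound 4 (0.08 log units; within the scatter), so with fluoro present the methylamino group is not required for a number of this size. Fluoro in place of hydrogen on an aromatic carbon gives a 110-fold lower number from compound 2 to compound 4 (2.03 log units; beyond the scatter), which ties the high number of compound 2 to the missing fluoro, not to the missing methylamino. Nothing available gives a reason for either step.

From the compounds shown here alone, whether methylamino would matter in a compound without fluoro remains open. So does whether chloro or methoxy could stand in for fluoro.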